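The compounds below may be only part of what the source reports. "The series", "measured", "known", "first", "only" and "open" are said of these compounds alone.

Of the compounds shown here, three on a shared core have numbers so far in a functional assay on MCF7 cells (Homo sapiens) for cytotoxicity, read by MTT assay, with a stated time of 48 h; on this read-out higher numbers stand for weaker inhibition and lower numbers for stronger inhibition: compound 1 (`Cc1ncc([N+](=O)[O-])n1CCSc1nnc(-c2ccccc2F)o1`) reads 20500 nM there, compound 2 (`Cc1ncc([N+](=O)[O-])n1CCSc1nnc(-c2ccco2)o1`) reads 29500 nM there, and compound 3 (`Cc1ncc([N+](=O)[O-])n1CCSc1nnc(-c2cccs2)o1`) reads 25800 nM in the same test. Compound 3 stands within the scatter of both others, so the three numbers give no order. The step to compound 4 (`Cc1ncc([N+](=O)[O-])n1CCSc1nnc(-c2cccnc2)o1`) is pyridin-3-yl in place of thiophen-2-yl on an aromatic carbon and amounts to pyridin-3-yl in place of thiophen-2-yl on an aromatic carbon. Among the compounds with values here, three measured steps bear on it, each a swap of one aromatic group for another on that same carbon. They are a 1.4-fold higher number from compound 1 to compound 2 (0.16 log units; within the scatter) and a 1.3-fold higher number from compound 1 to compound 3 (0.10 log units; within the scatter) and a 1.1-fold lower number from compound 2 to compound 3 (0.06 log units; within the scatter) and none leaves the scatter. Within the data shown here, no measured compound carries pyridin-3-yl, so the expectation is an extrapolation. Taking a 1.1-fold lower number from compound 2 to compound 3 (0.06 log units; within the scatter) as a guide, no change beyond the scatter is expected in this assay for this swap. The expected step is a 1.1-fold higher number from compound 3 to compound 4 (0.04 log units; within the scatter) and nothing larger. The estimated value for compound 4 is 28000 nM (expected range 13000 nM to 60000 nM).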

Compound 4, half-maximal inhibitory concentration: 28700 nM
The estimate for compound 4 lay 1.0-fold (0.01 log units) below the measured number; the measured number falls inside the stated range.
By their numbers in this assay, from the lowest: compounds 1, 3, 4 and 2 (each within the scatter of the next).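

In this assay, compound 4 puts a six-membered aromatic ring with a ring nitrogen on this aromatic carbon, and the swaps give a 1.1-fold higher number from compound 3 to compound 4 (0.05 log units; within the scatter), a 1.0-fold lower number from compound 2 to compound 4 (0.01 log units; within the scatter) and a 1.4-fold higher number from compound 1 to compound 4 (0.15 log units; within the scatter). Pyridin-3-yl thus joins 2-fluorophenyl, furan-2-yl and thiophen-2-yl with no step among these four compounds leaving the scatter, so ring size and the kind of hetero atom in the group bring out no order among them here. No measurement shown offers an explanation for this flat picture.

Going by these compounds, it remains open whether a group of another kind on this carbon, such as an amine, a carboxylic acid or a longer chain, would leave the scatter. The compounds shown also leave open what a change elsewhere on the shared core would do.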